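Swapping a Cyanophenyl for Cyclohexyl: Solubility Outlook

The compounds below may be only part of what the source reports. "The series", "measured", "known", "first", "only" and "open" are said of these compounds alone.

Compound 1 `COc1ccc(Oc2ccc3c(NCCCNCc4cccc(OC)c4O)ccnc3c2)cc1` gives 14500 nM in a physicochemical assay for solubility, with a stated time of 18 h, at pH 7.4; a higher number here means a more soluble compound, a lower number a less soluble compound.
Compound 2 `COc1cccc(CNCCCNc2ccnc3cc(Oc4ccccc4)ccc23)c1O` gives 14500 nM in this assay.
Compound 3 `COc1cccc(CNCCCNc2ccnc3cc(Cc4ccc(C#N)cc4)ccc23)c1O` gives 4200 nM in this assay.

Compound 3 stands lowest of the three numbers. Among the measured compounds shown here, both other compounds sit the same distance above it: a 3.5-fold lower number from compound 1 to compound 3 (0.54 log units; beyond the scatter) and a 3.5-fold lower number from compound 2 to compound 3 (0.54 log units; beyond the scatter), the only two steps measured here, and both lie beyond the scatter. They show that exchanging the group on this carbon of the shared core moves solubility modestly, while the step of no change at the digits printed from compound 1 to compound 2 (within the scatter) shows a smaller change elsewhere leaving the number unchanged.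

The next compound, compound 4 `COc1cccc(CNCCCNc2ccnc3cc(CC4CCCCC4)ccc23)c1O`, differs from compound 3 only at that same group: cyclohexyl in place of 4-cyanophenyl on a saturated chain carbon bound to an aromatic carbon. For the measured compounds named here, no measured step mirrors this particular exchange, so the direction cannot be read straight from the data; the two steps that reach compound 3 only indicate that changes at this position have so far been modest in size. A modest downward step is therefore expected, a 1.7-fold lower number from compound 3 to compound 4 (0.23 log units; within the scatter), with wide uncertainty in either direction. For compound 4 in this assay the estimate is 2500 nM, expected to fall between 700 nM and 9000 nM.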

Compound 4, solubility: 4200 nM
Compound 4: the middle estimate sits 1.7-fold (0.23 log units) below what was measured; measured number inside the range.
By their numbers in this assay, from the lowest: compounds 3 and 4 (each within the scatter of the next); then compounds 1 and 2 (each within the scatter of the next).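

In this assay, replacing 4-cyanophenyl with cyclohexyl takes away an aromatic ring, a triple bond and a hydrogen-bond acceptor from this group, yet the result is no change at the digits printed from compound 3 to compound 4 (within the scatter). Compound 4 also shows the same drop as compound 3 against the two compounds with an oxygen-linked ring, with cyclohexylmethyl in place of phenoxy giving a 3.5-fold lower number from compound 2 to compound 4 (0.54 log units; beyond the scatter) and cyclohexylmethyl in place of 4-methoxyphenoxy giving a 3.5-fold lower number from compound 1 to compound 4 (0.54 log units; beyond the scatter), so two quite different groups, 4-cyanobenzyl and cyclohexylmethyl, now share one level, with phenoxy and 4-methoxyphenoxy sharing a higher one. Nothing available here explains why the groups fall into these two levels.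

The compounds shown leave open whether the gap between the two levels follows the link to the core or the ring beyond it, a question that a cyclohexyloxy group at this place could help to separate. Also open, going by these compounds, is whether a ring carrying an amine or a carboxylic acid here would move the number away from that of compound 3 and compound 4 at all.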